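Swapping Benzoyl Halogens in a Series at the Limit

The source may hold more compounds than are shown below. What is called first, only, known or untested is meant among the compounds shown, and "the series" means these compounds.

Compound 1 `O=C(Nc1ccc(Cl)c(-c2nnc3c(Cl)cccn23)c1)c1ccc(F)cc1Cl` and compound 2 `O=C(Nc1ccc(Cl)c(-c2nnc3c(Cl)cccn23)c1)c1ccc(Cl)cc1Cl` share one core and differ by a single exchange, chloro in place of fluoro on an aromatic carbon. In a functional assay on T47D cells (Homo sapiens) for antiproliferative activity, read by MTT assay, with a stated time of 72 h (on this read-out lower numbers stand for stronger inhibition and higher numbers for weaker inhibition), compound 1 reaches only the limit of the assay, > 100000 nM. In this assay compound 2 likewise stops at the assay's limit, > 100000 nM. The step that the two limits leave unreadable from compound 1 to compound 2 cannot be read, since both of its ends are limits (the limit of > 100000 nM in this assay, at which 2 of the 2 values shown sit). Among the compounds with values here, this is where compound 2 stands: no number of its own, only a limit, and the one other measurement is a limit as well.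

Compound 3 `O=C(Nc1ccc(Cl)c(-c2nnc3c(Cl)cccn23)c1)c1c(F)cccc1Cl` has not yet been measured. It differs from compound 2 by 2-chloro-6-fluorophenyl in place of 2,4-dichlorophenyl on a carbonyl carbon. Within the data shown here, the single measured step is unreadable, so no measured step tells how a change on this part of the molecule moves the read-out. Among the measured compounds shown here, the only guide is that both measured compounds sit at the limit (the limit of > 100000 nM in this assay, at which 2 of the 2 values shown sit). Compound 3 is therefore expected to sit near that limit too, with the step of a number no higher from compound 2 to compound 3 (the limit leaves the size open) expected to be small. The estimate for compound 3 is 100000 nM, with a range from 30000 nM to 300000 nM.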

Compound 3, half-maximal inhibitory concentration: > 100000 nM
Compound 3 ended at the assay's limit (the forecaster's own chance of this, stated with the estimate: 75%); the middle value sits exactly at the limit.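

In this assay compound 3 gives > 100000 nM, which is a limit and not a number, so its steps to compound 2 and compound 1 cannot be read: the limit of > 100000 nM in this assay, at which 3 of the 3 values shown sit.

The compounds shown leave open whether 2-chloro-6-fluorophenyl in place of 2,4-dichlorophenyl moves the read-out in this assay at all, and what true value any of the three compounds has.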